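The compounds below may be only part of what the source reports. "The series", "measured", "known", "first", "only" and "open" are said of these compounds alone.

Measured compounds:
compound 1, `COc1cc(-c2nnc3n2NC(c2cccs2)C(C(=O)c2ccccc2)S3)cc(OC)c1OC`: 69400 nM
compound 2, `COc1ccc(C(=O)C2Sc3nnc(-c4cc(OC)c(OC)c(OC)c4)n3NC2c2ccco2)cc1`: > 100000 nM, a limit of the assay and not a number
compound 3, `COc1cc(-c2nnc3n2NC(c2cccs2)C(C(=O)c2ccc(Cl)cc2)S3)cc(OC)c1OC`: 20100 nM

In a functional assay on A549 cells (Homo sapiens) for cytotoxicity, read by MTT assay, with a stated time of 48 h (on this read-out higher numbers stand for weaker inhibition and lower numbers for stronger inhibition), compound 2 gives > 100000 nM, which is a limit of the assay and not a number (the limit of > 100000 nM in this assay, at which 1 of the 3 values shown sits). Going by the values given here, compound 1 gives 69400 nM and compound 3 gives 20100 nM; the only step measured in a single place is a 3.5-fold lower number from compound 1 to compound 3 (0.54 log units; beyond the scatter), a change on the ring attached to the carbonyl carbon. Compound 4, `COc1cc(-c2nnc3n2NC(c2ccco2)C(C(=O)c2ccccc2C)S3)cc(OC)c1OC`, differs from compound 2 on that same carbonyl carbon: 2-methylphenyl in place of 4-methoxyphenyl on a carbonyl carbon. Among the compounds with values here, the measured step replaces hydrogen with chloro, not methoxy with methyl, so it shows only that a single change on that ring moves the number modestly, and it gives no direction for the present change. With compound 2 resting at a limit, the step to compound 4 has no firm starting number; the expectation is therefore a value near the upper end of the range covered by compound 1 and compound 3, with a sizeable chance that compound 4 also returns only a limit. Compound 4 is estimated in this assay at 65000 nM, within 25000 nM to 160000 nM. The step this estimate implies is an at least 1.5-fold lower number from compound 2 to compound 4 (0.18 log units; that floor lies within the scatter), expected rather than measured.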

Compound 4, half-maximal inhibitory concentration: 80000 nM
Compound 4: the middle estimate sits 1.2-fold (0.09 log units) below what was measured; measured number inside the range.
By their numbers in this assay, from the lowest: compound 3; then compounds 1 and 4 (each within the scatter of the next). At a limit, above all of these: compound 2.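

In this assay compound 4 gives 80000 nM, so a 2-methylphenyl on this carbonyl carbon yields a reading on the scale of the assay. Compound 2 gives > 100000 nM, which is a limit of the assay and not a number. The change from 4-methoxyphenyl to 2-methylphenyl can therefore be read only as an at least 1.2-fold lower number from compound 2 to compound 4 (0.09 log units; that floor lies within the scatter), which gives its direction at this position but leaves its full size unfixed: the limit of > 100000 nM in this assay, at which 1 of the 4 values shown sits.

The compounds shown leave open whether this step belongs to the methoxy group leaving, to the methyl group entering, or to where each sits on the phenyl ring. Also open, from the compounds shown here alone, are how an amine or a carboxylic acid on that phenyl ring would read and whether a 3.5-fold lower number from compound 1 to compound 3 (0.54 log units; beyond the scatter) would carry over to the core of compound 4.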